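This account rests on a few compounds, and the source may have more. Where it says the series, first, only, none or still open, it means among the compounds named here.

Measured compounds in a functional assay for antagonist activity at transient receptor potential cation channel subfamily V member 1 (Homo sapiens), read by FLIPR; a higher number here means a weaker inhibitor, a lower number a stronger inhibitor:
- compound 1, `CC(C)(C)c1ccc(NC(=O)c2ccc(-c3ccccn3)cc2)cc1`: 11 nM
- compound 2, `CC(C)(C)c1ccc(NC(=O)c2ccc(-c3ncccc3C#N)cc2)cc1`: 30 nM

Compound 1 stands lowest of the two numbers; its nearest neighbour is compound 2, with a 2.7-fold higher number from compound 1 to compound 2 (0.44 log units; beyond the scatter). Compound 3, `Cc1nnc(-c2cccnc2-c2ccc(C(=O)Nc3ccc(C(C)(C)C)cc3)cc2)o1`, is not yet measured. It differs from compound 1 by 5-methyl-1,3,4-oxadiazol-2-yl in place of hydrogen on an aromatic carbon. Going by the values given here, the one measured step that bears on this change is the one from compound 1 to compound 2, where a cyano entered on an aromatic carbon of the shared core and the number rose modestly. The 5-methyl-1,3,4-oxadiazol-2-yl entering in compound 3 is a larger substituent, also 0 hydrogen-bond donors and 3 hydrogen-bond acceptors, on the same core. A rise of similar, modest size is therefore expected for compound 3, a 3.6-fold higher number from compound 1 to compound 3 (0.56 log units; beyond the scatter). Compound 3 is estimated at 40 nM in this assay, within a range of 14 nM to 120 nM.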

Compound 3, half-maximal inhibitory concentration: 387 nM
The estimate for compound 3 lay 9.7-fold (0.99 log units) below the measured number, and the stated range ends below it.
By their numbers in this assay, from the lowest: compound 1; then compound 2; then compound 3.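

In this assay, the aromatic carbon ortho to a large group, two atoms from the ring nitrogen, accepts the two entering groups very differently: 5-methyl-1,3,4-oxadiazol-2-yl gives a large step (a 35-fold higher number from compound 1 to compound 3 (1.55 log units; beyond the scatter)), while cyano gave a modest one (a 2.7-fold higher number from compound 1 to compound 2 (0.44 log units; beyond the scatter)). The direct exchange of cyano for 5-methyl-1,3,4-oxadiazol-2-yl is also large (a 13-fold higher number from compound 2 to compound 3 (1.11 log units; beyond the scatter)), so the modest cyano step does not carry over to every substituent at this position. Nothing measured on these compounds accounts for the difference between the two groups.

Two substituents cannot show whether the rise follows the size of the entering group or is particular to 5-methyl-1,3,4-oxadiazol-2-yl. A methyl, a chlorine or a primary amine on the same carbon would help separate these readings.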